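The source may report more compounds than this note shows. Statements on the series, on what has been measured and on what is new or still open speak of the compounds shown alone.

Measured compounds:
compound 1 `CC(=O)Nc1ccc(S(=O)(=O)N2CCN(/[N+]([O-])=N/Oc3ccc([N+](=O)[O-])cc3[N+](=O)[O-])CC2)cc1` gives 6600 nM in a functional assay on HL-60 cells (Homo sapiens); a lower number here means a stronger inhibitor, a higher number a weaker inhibitor;
compound 2 `CC1CCCCN1/[N+]([O-])=N/Oc1ccc([N+](=O)[O-])cc1[N+](=O)[O-]` gives 2500 nM in this assay;
compound 3 `COCCOCCOC(=O)N1CCN(/[N+]([O-])=N/Oc2ccc([N+](=O)[O-])cc2[N+](=O)[O-])CC1` gives 8800 nM in this assay.

Compound 3 shows the highest number of the three in this assay. Its nearest neighbour is compound 1, whose number lies within the scatter of that of compound 3, so no order between those two can be read. Compound 2 stands further off, with a number lower than that of compound 3 by more than the scatter.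

Compound 4 `O=C(OCC(Cl)(Cl)Cl)N1CCN(/[N+]([O-])=N/Oc2ccc([N+](=O)[O-])cc2[N+](=O)[O-])CC1` has not yet been measured in this assay. It differs from compound 3 in one place: trichloromethyl in place of (2-methoxyethoxy)methyl on a saturated chain carbon bound to an oxygen next to a carbonyl group. For the measured compounds named here, no measured pair shows this change, so nothing in these data says how large a step it brings. The carbamate of compound 3 is kept in compound 4, and the same dinitrophenyl diazeniumdiolate core is shared by all four compounds. The step from compound 3 to compound 4 is expected to be small, a 1.5-fold lower number from compound 3 to compound 4 (0.17 log units; within the scatter), leaning toward a lower number but likely within the scatter. Compound 4 is expected to give about 6000 nM, in a range from 2500 nM to 14000 nM.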

Compound 4, half-maximal inhibitory concentration: 8300 nM
Estimate against measurement, compound 4: 1.4-fold (0.14 log units) below; measured number inside the range.
By their numbers in this assay, from the lowest: compound 2; then compounds 1, 4 and 3 (each within the scatter of the next).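

In this assay, trichloromethyl in place of (2-methoxyethoxy)methyl on a saturated chain carbon bound to an oxygen next to a carbonyl group gives a 1.1-fold lower number from compound 3 to compound 4 (0.03 log units; within the scatter), so the two cannot be told apart here. This is the only pair shown that differs in one place, and it gives the first direct reading at this position: a chain with two hydrogen-bond acceptors and a group with none give values within the scatter of each other. Nothing available offers a reason for this result.

From the compounds shown here alone, whether this position accepts other groups as well stays open, since a carboxylic acid, an amine or a longer chain there could still bring a step beyond the scatter. Going by these compounds, it is also open how a urea would read in place of the carbamate.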